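A few compounds are considered here, and "the series" means these few. Any claim that something is new, unique, unknown or untested is made for them only; others in the source may bear on it.

The three measured compounds, each in an assay for inhibition of histone acetyltransferase KAT2B (Homo sapiens); a lower number here means a stronger inhibitor, a higher number a weaker inhibitor:

compound 1 `CN(C)c1ccc(-n2sccc2=O)cc1` gives 5400 nM;
compound 2 `O=c1cc(CO)sn1-c1ccccc1` gives 109000 nM;
compound 3 `CC(=O)OCc1cc(=O)n(-c2ccccc2)s1` gives 162000 nM.

Compound 3 sits at the weak end of this small set. Against compound 1 its number is far higher, a gap well beyond the scatter of repeat measurements. Against compound 2 the picture is different: the step of a 1.5-fold higher number from compound 2 to compound 3 (0.17 log units; within the scatter) lies within the scatter, so compound 2 and compound 3 cannot be told apart on these data.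

Compound 4 `O=C(Nc1ccccc1)OCc1cc(=O)n(-c2ccccc2)s1` differs from compound 3 in one place: anilino in place of methyl on a carbonyl carbon. Within the data shown here, only one measured step touches this part of the molecule, the step of a 1.5-fold higher number from compound 2 to compound 3 (0.17 log units; within the scatter), and it was within the scatter; nothing measured here swaps a methyl for an anilino anywhere, so no direct precedent exists for the change itself. On that basis the step of a 1.2-fold lower number from compound 3 to compound 4 (0.10 log units; within the scatter) is expected to stay within the scatter, with no clear direction. Compound 4 is therefore estimated at 130000 nM in this assay, in a range from 40000 nM to 400000 nM, with a real chance that only a limit is reported.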

Compound 4, half-maximal inhibitory concentration: > 200000 nM
Compound 4 was reported as a limit; the forecaster's own chance of this, stated with the estimate: 25%; middle value at least 1.5-fold (0.18 log units) away from the limit.
By their numbers in this assay, from the lowest: compound 1; then compounds 2 and 3 (each within the scatter of the next). At a limit, above all of these: compound 4.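

In this assay, replacing methyl with anilino on a carbonyl carbon gives an at least 1.2-fold higher number from compound 3 to compound 4 (0.09 log units; that floor lies within the scatter). The value of compound 4 is a limit, not a measured number: the limit of > 200000 nM in this assay, at which 1 of the 4 values shown sits. This is the first change shown on this carbonyl carbon, and although anilino brings in a six-membered aromatic ring and a hydrogen-bond donor, it yields no sign of a stronger inhibitor, while the floor of the step is too small to show that compound 4 is truly a weaker inhibitor than compound 3.

The compounds shown leave open how far the true value of compound 4 lies past its limit, and therefore how large this step really is. They also leave open whether a different group on the same carbonyl carbon, such as a plain amino group, a methoxy group or a longer alkyl chain, would lower the number in this assay, or whether this carbonyl carbon offers little room for improvement whichever group it carries.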